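From fluoro to ethynyl on the amide aromatic ring

The source may hold more compounds than are shown below. What is called first, only, known or untested is meant among the compounds shown, and "the series" means these compounds.

In a functional assay on MDA-MB-231 cells (Homo sapiens) for antiproliferative activity, read by MTT assay, with a stated time of 72 h (a lower number here means a stronger inhibitor, a higher number a weaker inhibitor), compound 1 (`CCNC(=O)CCc1cccc2c1B(O)OC2`) gives > 100000 nM, which is a limit of the assay and not a number. Among the compounds with values here, compound 2 (`O=C(CCc1cccc2c1B(O)OC2)Nc1ccc(F)cc1`) gives 440 nM, the only actual number so far. Within the data shown here, the sole measured step, an at least 220-fold lower number from compound 1 to compound 2 (2.35 log units; beyond the scatter), is large and places 4-fluorophenyl in place of ethyl on an amide-type nitrogen.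

Compound 3 (`C#Cc1ccc(NC(=O)CCc2cccc3c2B(O)OC3)cc1`) follows from compound 2 by ethynyl in place of fluoro on an aromatic carbon, para to a large group. The step to compound 2, an at least 220-fold lower number from compound 1 to compound 2 (2.35 log units; beyond the scatter), keeps no aromatic group on both sides, so it gives no measured size for this exchange. No clear direction and no step beyond the scatter are therefore expected in this assay. The estimated change is a 1.1-fold higher number from compound 2 to compound 3 (0.06 log units; within the scatter). Compound 3 is expected at 500 nM, with an estimated range of 130 nM to 2000 nM.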

Compound 3, half-maximal inhibitory concentration: 6600 nM
Compound 3: middle estimate off by 13-fold (1.12 log units), on the low side; the whole stated range lies below it.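

In this assay, ethynyl in place of fluoro on an aromatic carbon, para to a large group, gives a 15-fold higher number from compound 2 to compound 3 (1.18 log units; beyond the scatter). The earlier step exchanged ethyl for the whole 4-fluorophenyl group, whereas this one shows that the outcome also depends on the group at this single ring position, even though 1 heavy atom of fluoro gives way to only 2 heavy atoms of ethynyl. Compound 3 still gives a measured value of 6600 nM, so the series keeps a readable number with ethynyl at this position, but the aromatic ring alone does not secure the level of compound 2.

Nothing shown here gives a measured cause for this step. From the compounds shown here alone, with only fluoro and ethynyl at this position, it remains open where chloro, methoxy, an amine or a carboxylic acid would fall relative to compound 2 and compound 3.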